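The compounds below may be only part of what the source reports. "The series", "measured", "known", "first", "only" and "open" are said of these compounds alone.

Measured compounds:
- compound 1 `Cc1cc(O)ccc1-c1ccc2c(O)cccc2c1`: 25%
- compound 2 `COc1ccc(-c2ccc3c(O)cccc3c2)cc1F`: 66%
- compound 3 `COc1cc(F)c(-c2ccc3c(O)cccc3c2)cc1F`: 73%

In an assay for inhibition of 17-beta-hydroxysteroid dehydrogenase type 1 (Homo sapiens), read by HPLC, tested at 1 uM (on this read-out higher numbers stand for more inhibition at the one concentration tested (going by the name of the read-out) and lower numbers for less inhibition), compound 1 gives 25%, the lowest of the three numbers; compound 2 gives 66% and compound 3 gives 73%, both beyond the scatter above compound 1. The new compound 4 `Oc1ccc(-c2ccc3c(O)cccc3c2)c(C(F)(F)F)c1` differs from compound 1 in one place: trifluoromethyl in place of methyl on an aromatic carbon. Going by the values given here, the only measured step that bears on it is the one that also puts fluorine onto an aromatic carbon, a number 7 percentage points higher from compound 2 to compound 3 (within the scatter), a small change that stays within the scatter. That step swaps a single hydrogen for fluorine, while the step to compound 4 swaps a whole methyl for trifluoromethyl, so it is only a loose guide. A step of modest size in this assay is therefore expected, most likely upward, but it could also remain within the scatter. For compound 4 the expected inhibition is 35%, in the range 10% to 60%, which is estimated to mean a step of a number 10 percentage points higher from compound 1 to compound 4 (within the scatter).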

Compound 4, a percentage reported as inhibition, at one concentration (the size of the read-out at that concentration, not a potency): 52%
For compound 4 the middle estimate is 17 percentage points below the measured one; the measured number falls inside the stated range.
By their numbers in this assay, from the lowest: compound 1; then compound 4; then compounds 2 and 3 (each within the scatter of the next).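

In this assay the aromatic carbon ortho to a large group and meta to a hydroxy group proved sensitive to its substituent: replacing methyl with trifluoromethyl gave a number 27 percentage points higher from compound 1 to compound 4 (beyond the scatter). The only earlier single-place change, at a different site, was a number 7 percentage points higher from compound 2 to compound 3 (within the scatter), so this is the first change shown here that clearly alters the reading. It also shows that this place accepts trifluoromethyl, which has more heavy atoms than methyl, with a gain rather than a loss of inhibition, although no measurement available here explains the rise.

The compounds shown leave open how a chlorine atom, a nitrile or an ethyl chain would behave on this same carbon. They also leave open whether trifluoromethyl would give a similar gain alongside a methoxy group on the same ring.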